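Swapping an Isobutyl Chain for a Fluorinated Ring

The compounds below may be only part of what the source reports. "The series", "measured", "known", "first", "only" and "open" are said of these compounds alone.

Measured so far in an ADME assay on 2209-23 cells (Homo sapiens) for cytotoxicity, read by WST assay and thymidine incorporation; a higher number here means that more compound is tolerated, a lower number that less compound is tolerated:
- compound 1, `CC(C)CCN1C(=O)C(C2=CS(=O)(=O)c3cc(NS(C)(=O)=O)ccc3N2)=C(O)[C@@H]1C(C)(C)C`: compound 1 gives > 50000 nM, which is a limit of the assay rather than a number.
- compound 2, `CC(C)(C)[C@H]1C(O)=C(C2=CS(=O)(=O)c3cc([N+](=O)[O-])ccc3N2)C(=O)N1Cc1ccc(F)cc1`: compound 2 gives > 50000 nM, again a limit of the assay.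
- compound 3, `CC(=O)C1=C(C2=C(O)[C@H](C(C)(C)C)N(Cc3ccc(F)cc3)C2=O)Nc2ccc(NS(C)(=O)=O)cc2S1(=O)=O`: compound 3 gives > 50000 nM, also a limit of the assay.

Compound 1 therefore stands nowhere in particular on a scale: for it, as for the other two, the cells tolerated the compound up to the highest concentration tested, and all three values sit at the same limit (the limit of > 50000 nM in this assay, at which 3 of the 3 values shown sit). Not one compound has yet given a true number in this assay, so no measured step of any size exists here.

The compound still to be tested is compound 4, `CC(C)(C)[C@H]1C(O)=C(C2=CS(=O)(=O)c3cc(NS(C)(=O)=O)ccc3N2)C(=O)N1Cc1ccc(F)cc1`. Its difference from compound 1 is this: 4-fluorophenyl in place of isobutyl on a saturated chain carbon bound to an amide-type nitrogen in a ring. Compound 2, which already carries the 4-fluorobenzyl group, sits at the limit like compound 1. Given this, the step from compound 1 to compound 4 is expected to be none beyond the usual scatter, a step that the limit leaves unreadable from compound 1 to compound 4, and most likely to end in a fourth limit. For compound 4 the estimated value in this assay is 60000 nM, expected to fall between 30000 nM and 200000 nM.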

Compound 4, half-maximal cytotoxic concentration: > 50000 nM
Compound 4 gave a limit, no number; the forecaster's own chance of this, stated with the estimate: 85%; the middle value does not contradict the limit.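

Compound 4 joins compound 1, compound 2 and compound 3 in this assay, and no step among them can be read, because each value is a limit and not a number: the limit of > 50000 nM in this assay, at which 4 of the 4 values shown sit.

The compounds shown leave open whether swapping isopentyl for 4-fluorobenzyl, or any other single change here, alters the concentration these cells tolerate.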